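Pyrrolyl in Place of Methoxyphenyl on a Prolinamide Orexin Ligand

The source may hold more compounds than are shown below. What is called first, only, known or untested is meant among the compounds shown, and "the series" means these compounds.

Compound 1 `COc1ccccc1-c1ccccc1NC(=O)[C@@H]1CCCN1C(=O)CCc1nc2ccccc2[nH]1`: 86 nM
Compound 2 `Cn1c(SCC(=O)N2CCC[C@H]2C(=O)Nc2ccccc2-c2ccccc2)nc2ccccc21`: 3 nM

In an assay on CHO cells for displacement of a labelled ligand from Orexin/Hypocretin receptor type 1 (Homo sapiens) (a lower number here means a stronger inhibitor, a higher number a weaker inhibitor), compound 1 gives 86 nM, the higher of the two numbers measured. Compound 2 gives 3 nM, a stronger value that sits beyond the scatter from compound 1; the two compounds differ in more than one place, so no single change can be tied to that gap. Compound 3 `O=C(Nc1ccccc1-n1cccc1)[C@@H]1CCCN1C(=O)CCc1nc2ccccc2[nH]1` differs from compound 1 in one place: 1H-pyrrol-1-yl in place of 2-methoxyphenyl on an aromatic carbon, a 1H-pyrrol-1-yl in place of 2-methoxyphenyl on an aromatic carbon, ortho to a large group. Among the measured compounds shown here, no measured pair shows this change, so the step from compound 1 to compound 3 is estimated at a 1.7-fold higher number from compound 1 to compound 3 (0.24 log units; within the scatter), expected to lie within the scatter or to be a small move toward a weaker value. For compound 3 the expected value in this assay is 150 nM, with a range of 40 nM to 600 nM.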

Compound 3, inhibition constant: 130 nM
For compound 3 the middle estimate is 1.2-fold (0.06 log units) above the measured one, and the stated range covers the measured number.
By their numbers in this assay, from the lowest: compound 2; then compounds 1 and 3 (each within the scatter of the next).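

In this assay, putting 1H-pyrrol-1-yl in place of 2-methoxyphenyl gives a 1.5-fold higher number from compound 1 to compound 3 (0.18 log units; within the scatter) and so leaves the two compounds within the scatter of each other. Among the compounds shown here, this is the first sign that this aromatic carbon, ortho to a large group, can carry a five-membered aromatic ring with 1 hetero atom instead of a six-membered aromatic ring of carbon only, with no step beyond the scatter. Nothing available explains why the two groups read alike.

The compounds shown leave open whether an amine or a carboxylic acid on this aromatic carbon would hold the number as well. They also leave open whether 1H-pyrrol-1-yl would read the same way on compound 2, which differs from compound 1 in more than one place.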